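Replacing a trifluoromethylphenyl by a nitrophenyl on the shared core

The source may report more compounds than this note shows. Statements on the series, on what has been measured and on what is new or still open speak of the compounds shown alone.

Compound 1 `O=C(CN1CCN(c2cccc(C(F)(F)F)c2)CC1)N(c1ccccc1)c1ccccc1` carries a 3-(trifluoromethyl)phenyl on the ring nitrogen of the shared core. In a toxicity assay on the whole organism (strain albino) for activation, with Mus musculus as the target, with stated times of 30 min and 240 min (on this read-out higher numbers stand for an effect only at larger amounts of compound and lower numbers for an effect already at smaller amounts), compound 1 gives 48 mg/kg. Compound 2 `O=C(CN1CCN(c2cccc(Cl)c2)CC1)N(c1ccccc1)c1ccccc1`, with chloro in place of trifluoromethyl on the aromatic carbon, gives 48.4 mg/kg in this assay, so the two numbers sit within the scatter of each other; the move is a 1.0-fold higher number from compound 1 to compound 2 (0.00 log units; within the scatter). For compound 3 `O=C(CN1CCN(c2ccc(F)cc2)CC1)N(c1ccccc1)c1ccccc1` this assay reports only a limit, > 40 mg/kg. Because of that limit of > 40 mg/kg in this assay, at which 1 of the 3 values shown sits, the step that the limit leaves unreadable from compound 1 to compound 3 cannot be sized, and the same holds for a step that the limit leaves unreadable from compound 2 to compound 3.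

Compound 4 `O=C(CN1CCN(c2ccc([N+](=O)[O-])cc2)CC1)N(c1ccccc1)c1ccccc1` differs from compound 1 by 4-nitrophenyl in place of 3-(trifluoromethyl)phenyl on an amine nitrogen in a ring. Both measured changes on that aromatic ring either stayed within the scatter or could not be read, so no step beyond the scatter is expected in this assay. Compound 4 is therefore estimated at 48 mg/kg, with a range from 25 mg/kg to 100 mg/kg, an expected step of no change at the digits printed from compound 1 to compound 4 (within the scatter).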

Compound 4, dose for half-maximal effect: > 40 mg/kg
Compound 4: a limit, no number (the forecaster's own chance of this, stated with the estimate: 30%); the middle value lies beyond the limit too.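

In this assay compound 4 gives only a limit, > 40 mg/kg. Its steps from compound 1, compound 2 and compound 3 therefore cannot be read: the limit of > 40 mg/kg in this assay, at which 2 of the 4 values shown sit.

The compounds shown leave open how far compound 3 and compound 4 actually lie from compound 1 and compound 2, and from each other.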